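Swapping the acyl group: from thiophene to an anilino urea

This account rests on a few compounds, and the source may have more. Where it says the series, first, only, none or still open, it means among the compounds named here.

Three compounds share one core and differ only in the group on the carbonyl carbon. In an ADME assay on Li23 cells (Homo sapiens) for cytotoxicity, read by WST assay (a lower number here means that less compound is tolerated, a higher number that more compound is tolerated), compound 1 `CN(C(=O)C1CCCCC1)c1ccc(C(O)(C(F)(F)F)C(F)(F)F)cc1` gives 20000 nM, compound 2 `CN(C(=O)c1cccnc1)c1ccc(C(O)(C(F)(F)F)C(F)(F)F)cc1` gives 63000 nM, and compound 3 `CN(C(=O)c1cccs1)c1ccc(C(O)(C(F)(F)F)C(F)(F)F)cc1` gives 33000 nM. Compound 3 stands second highest of the three, but its neighbours sit close: a 1.7-fold higher number from compound 1 to compound 3 (0.22 log units; within the scatter) and a 1.9-fold lower number from compound 2 to compound 3 (0.28 log units; within the scatter), whereas a 3.2-fold higher number from compound 1 to compound 2 (0.50 log units; beyond the scatter). Compound 4 `CN(C(=O)Nc1ccccc1)c1ccc(C(O)(C(F)(F)F)C(F)(F)F)cc1` carries the change (anilino in place of thiophen-2-yl on a carbonyl carbon). The three measured swaps at this carbon moved the numbers modestly at most, so for compound 4 the expected step is a 1.2-fold higher number from compound 3 to compound 4 (0.08 log units; within the scatter), with no shift beyond the scatter anticipated. The estimate for compound 4 in this assay is 40000 nM, within a range from 15000 nM to 100000 nM.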

Compound 4, half-maximal cytotoxic concentration: > 20000 nM
Compound 4 was reported as a limit; the forecaster's own chance of this, stated with the estimate: 10%; the middle value does not contradict the limit.
By their numbers in this assay, from the lowest: compounds 1, 3 and 2 (each within the scatter of the next, the first and the last beyond it).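

In this assay compound 4 gives a limit, not a number: the limit of > 20000 nM in this assay, at which 1 of the 4 values shown sits. Anilino is the first group on this carbonyl carbon joined through nitrogen and the first carrying a hydrogen-bond donor, and it still gives a number no lower from compound 1 to compound 4 (the limit leaves the size open), so this change does not lower the number relative to the cyclohexyl amide. The steps from compound 2 and from compound 3 cannot be read.

Going by these compounds, whether anilino truly matches thiophen-2-yl or pyridin-3-yl stays open. So does the effect of a benzylamino or dimethylamino group at this carbon.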